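A few compounds are considered here, and "the series" means these few. Any claim that something is new, unique, unknown or untested is made for them only; others in the source may bear on it.

Measured so far:
- compound 1 `Cc1ccc(C(=O)Nc2cccc(-c3oc4cc(-c5ccc(F)cc5)ccc4c(=O)c3O)c2)cc1` — 4350 nM in a functional assay on MDA-MB-231 cells (Homo sapiens) for antiproliferative activity, read by CCK-8 assay, with a stated time of 72 h; a higher number here means a weaker inhibitor, a lower number a stronger inhibitor
- compound 2 `O=C(Nc1cccc(-c2oc3cc(-c4ccc(F)cc4)ccc3c(=O)c2O)c1)c1ccc(-c2ccccc2)cc1` — 63200 nM in this assay

Compound 2 holds the highest of the two numbers in this assay; its nearest neighbour is compound 1, reached by the step of a 15-fold higher number from compound 1 to compound 2 (1.16 log units; beyond the scatter). Going by the values given here, that is the only measured step, and it is the one that bears on compound 3 `CCCc1ccc(C(=O)Nc2cccc(-c3oc4cc(-c5ccc(F)cc5)ccc4c(=O)c3O)c2)cc1`, which is obtained from compound 2 by propyl in place of phenyl on an aromatic carbon. The group that leaves is the one whose entry, on going from compound 1 to compound 2, brought the large rise in the number; the propyl that enters is a chain of three carbons, so compound 3 sits between compound 1 and compound 2 in the size of the group at that aromatic carbon. On that basis compound 3 is expected to move back toward compound 1, by roughly a 5.3-fold lower number from compound 2 to compound 3 (0.72 log units; beyond the scatter). The estimate for compound 3 in this assay is 12000 nM, within a range of 4000 nM to 40000 nM.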

Compound 3, half-maximal inhibitory concentration: 32200 nM
For compound 3 the middle estimate is 2.7-fold (0.43 log units) below the measured one; measured number inside the range.
By their numbers in this assay, from the lowest: compound 1; then compounds 3 and 2 (each within the scatter of the next).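

In this assay, the 4-phenylphenyl to 4-propylphenyl change gives a step within the scatter (a 2.0-fold lower number from compound 2 to compound 3 (0.29 log units; within the scatter)), so the two groups are not separated at this aromatic carbon, and the six-membered aromatic ring of the phenyl is not needed for a number of this size. Against the methyl of compound 1, propyl also gives a step beyond the scatter (a 7.4-fold higher number from compound 1 to compound 3 (0.87 log units; beyond the scatter)), so among these three compounds, both larger groups stand apart from methyl, one with a ring and one without. No measurement in hand explains this difference.

The compounds shown leave open how the number runs from methyl to propyl, which an ethyl group at the same carbon would help to fill in. Also open, going by these compounds, is whether a propyl chain ending in an amine or a carboxylic acid would read like propyl itself.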